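A few compounds are considered here, and "the series" means these few. Any claim that something is new, unique, unknown or untested is made for them only; others in the source may bear on it.

Measured in a functional assay on T47D cells (Homo sapiens) for inhibition, read by sulforhodamine B assay, with a stated time of 48 h; on this read-out higher numbers stand for weaker inhibition of growth and lower numbers for stronger inhibition of growth:
compound 1 `COC(=O)[C@@]1(C)CCC=C2[C@@H]1CC[C@@H](C)[C@]2(C)Cc1c[nH]c2ccc(Br)cc12` gives 16000 nM
compound 2 `COC(=O)[C@@]1(C)CCC=C2[C@@H]1CC[C@@H](C)[C@]2(C)Cc1c(C)[nH]c2ccccc12` gives 17000 nM
compound 3 `COC(=O)[C@@]1(C)CCC=C2[C@@H]1CC[C@@H](C)[C@]2(C)Cc1c(C)[nH]c2ccc(Br)cc12` gives 16000 nM

Compound 3 stands level with compound 1 and within the scatter of compound 2, so the three numbers cannot be told apart. Compound 4 `COC(=O)[C@@]1(C)CCC=C2[C@@H]1CC[C@@H](C)[C@]2(C)Cc1c(C)[nH]c2ccc(OC)cc12` differs from compound 3 by methoxy in place of bromo on an aromatic carbon. For the measured compounds named here, no measured step exchanges bromo for methoxy. The nearest guide is a 1.1-fold lower number from compound 2 to compound 3 (0.03 log units; within the scatter), which shows that adding a bromo at this carbon altered nothing beyond the scatter; no change at the digits printed from compound 1 to compound 3 (within the scatter) likewise shows that the methyl on the shared core made no difference. Because a 1.1-fold lower number from compound 2 to compound 3 (0.03 log units; within the scatter) was flat, the new swap is expected to give no step beyond the scatter in this assay, a 1.1-fold higher number from compound 3 to compound 4 (0.03 log units; within the scatter). Compound 4 is estimated at 17000 nM, with a range from 8000 nM to 36000 nM.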

Compound 4, concentration for 50% growth inhibition: 15000 nM
Estimate against measurement, compound 4: 1.1-fold (0.05 log units) above; the measured number falls inside the stated range.
By their numbers in this assay, from the lowest: compounds 4, 1, 3 and 2 (each within the scatter of the next).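

The earlier compounds shown here carried only hydrogen or bromo at this carbon. In this assay methoxy, which brings a hydrogen-bond acceptor, also stays within the scatter: a 1.1-fold lower number from compound 3 to compound 4 (0.03 log units; within the scatter) and a 1.1-fold lower number from compound 2 to compound 4 (0.05 log units; within the scatter) are both too small to read as real changes. Hydrogen, bromo and methoxy at this carbon therefore give numbers that cannot be told apart, and no measured evidence accounts for this flat result.

Going by these compounds, whether an amine or a carboxylic acid at this carbon would move the number beyond the scatter remains open. So does whether any change elsewhere on the shared core would do so.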